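The compounds below may be only part of what the source reports. "The series", "measured", "known", "first", "only" and "open" are said of these compounds alone.

Measured in an assay on isolated protein for binding affinity to adenosine receptor A1 (Bos taurus); a higher number here means a weaker inhibitor, a lower number a stronger inhibitor:
- compound 1 `OCCNc1nc(-c2ccccc2)nc2c1nnn2Cc1ccccc1` gives 38000000 nM
- compound 2 `Clc1ccccc1Cn1nnc2c(NC3CCC3)nc(-c3ccccc3)nc21` gives 24000000 nM
- compound 3 `FC(F)(F)c1ccccc1Cn1nnc2c(NC3CCCC3)nc(-c3ccccc3)nc21` gives 600000 nM

Compound 3 holds the lowest number of the three; the values of compound 2 and of compound 1 both lie beyond the scatter above it, so compound 3 is the strongest of the measured set in this assay.

Compound 4 `FC(F)(F)c1ccccc1Cn1nnc2c(NC3CCCCC3)nc(-c3ccccc3)nc21` is not yet measured. It differs from compound 3 in one place: cyclohexyl in place of cyclopentyl on a nitrogen on an aromatic ring. Within the data shown here, no pair of measured compounds shares this change, so the size of the step rests on nothing but the structural difference itself. The expected step in this assay is small, most likely within the scatter, with a slight lean toward a lower number: a 1.5-fold lower number from compound 3 to compound 4 (0.18 log units; within the scatter). Compound 4 is therefore estimated at 400000 nM, with a range from 100000 nM to 2000000 nM.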

Compound 4, inhibition constant: 6800000 nM
Estimate against measurement, compound 4: 17-fold (1.23 log units) below, outside the stated range (above it).
By their numbers in this assay, from the lowest: compound 3; then compound 4; then compounds 2 and 1 (each within the scatter of the next).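

In this assay, cyclohexyl in place of cyclopentyl on a nitrogen on an aromatic ring gives an 11-fold higher number from compound 3 to compound 4 (1.05 log units; beyond the scatter), so the ring on this nitrogen alone moves the number beyond the scatter. The earlier compounds shown here differ from one another in more than one place and could not isolate this position. No measured evidence bears on what lies behind this step.

Still open, from the compounds shown here alone, is how a cycloheptyl ring or an open pentyl chain on this nitrogen would read. Also open, going by these compounds, is whether the step keeps its size with a different group elsewhere on the shared core.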